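The source may report more compounds than this note shows. Statements on the series, on what has been measured and on what is new or still open speak of the compounds shown alone.

Compound 2 `COC(=O)c1ccc(CN(CCCc2c(N)nc(N)nc2O)c2cc(F)c(F)cc2[N+](=O)[O-])cc1` and compound 1 `COC(=O)c1ccc(CN(CCCc2c(N)nc(N)nc2O)c2cc(F)c([N+](=O)[O-])cc2[N+](=O)[O-])cc1` share one core and differ in a single place: nitro in place of fluoro on an aromatic carbon. In a functional assay on CCRF-CEM cells (Homo sapiens) for cytotoxicity, in the absence of a further agent (on this read-out higher numbers stand for weaker inhibition and lower numbers for stronger inhibition), compound 2 gives 66000 nM, and compound 1 gives 4300 nM, so that a 15-fold lower number from compound 2 to compound 1 (1.19 log units; beyond the scatter). Compound 3 `Nc1nc(N)c(CCCN(Cc2ccc(NC(CCC(=O)O)C(=O)O)cc2)c2ccc([N+](=O)[O-])c(F)c2F)c(O)n1` carries another core; the difference between the cores of compound 2 and compound 3 is not broken down here. In this assay compound 3 reaches only a limit, > 100000 nM. That limit is the limit of > 100000 nM in this assay, at which 1 of the 3 values shown sits. Compound 4 `Nc1nc(N)c(CCCN(Cc2ccc(NC(CCC(=O)O)C(=O)O)cc2)c2ccc([N+](=O)[O-])c(F)c2[N+](=O)[O-])c(O)n1` has not been measured; it differs from compound 3 in one place: nitro in place of fluoro on an aromatic carbon. The surroundings of the two changes are not the same word for word: in compound 1 the entering nitro group stands para to a large group, whereas in compound 4 it stands ortho to a large group, so the two are the same kind of change rather than the same change. Because a 15-fold lower number from compound 2 to compound 1 (1.19 log units; beyond the scatter) was large, a step of similar direction is expected here, an at least 3.3-fold lower number from compound 3 to compound 4 (0.52 log units; beyond the scatter). The value of compound 3 is only a limit, and the expected size of that step therefore rests on one measured step alone. The estimate for compound 4 in this assay is 30000 nM, between 5000 nM and 200000 nM.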

Compound 4, half-maximal inhibitory concentration: 46000 nM
The estimate for compound 4 lay 1.5-fold (0.19 log units) below the measured number; the range from low to high includes it.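

In this assay, carrying nitro in place of fluoro on an aromatic carbon over to the core of compound 3 gave an at least 2.1-fold lower number from compound 3 to compound 4 (0.33 log units; beyond the scatter), the same direction as on the core of compound 2. The value of compound 3, > 100000 nM, is a limit and not a number. This shows that the direction held on both cores, but with only two pairs it establishes no general rule, and the true size of the second step remains unknown, so the two steps cannot be ranked: the same change on two cores in this assay, a 15-fold lower number (1.19 log units; beyond the scatter) from compound 2 to compound 1 and an at least 2.1-fold lower number (0.33 log units; beyond the scatter) from compound 3 to compound 4; the limit leaves it open whether they differ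

The compounds shown leave open whether another group on the same aromatic carbon, such as a nitrile or a trifluoromethyl group, would give a step in the same direction as nitro. They also leave open whether the step would persist with a longer chain in place of the one joining the diaminopyrimidine-bearing part to the nitrogen.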